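Cytotoxicity of a thiocarbamate series: from compound 2 to compound 4

A few compounds are considered here, and "the series" means these few. Any claim that something is new, unique, unknown or untested is made for them only; others in the source may bear on it.

Measured compounds:
- compound 1, `O=C1c2ccccc2C(=O)N1CCOC(=S)N(C(=O)c1ccc(F)cc1F)c1ccc(Cl)cc1`: 52000 nM
- compound 2, `O=C1c2ccccc2C(=O)N1CCOC(=S)N(C(=O)c1ccc(Cl)cc1Cl)c1ccc(Cl)cc1`: 18000 nM
- compound 3, `Cc1ccc(N(C(=O)c2ccc(Cl)cc2Cl)C(=S)OCCN2C(=O)c3ccccc3C2=O)cc1`: 49000 nM

Within the data shown here, in an ADME assay on MT4 cells (Homo sapiens) for cytotoxicity, read by MTT assay (a lower number here means that less compound is tolerated, a higher number that more compound is tolerated), compound 2 gives the lowest of the three numbers so far. The nearest of the others is compound 3, reached by a 2.7-fold higher number from compound 2 to compound 3 (0.43 log units; beyond the scatter); the furthest is compound 1, and the step the other way, a 2.9-fold lower number from compound 1 to compound 2 (0.46 log units; beyond the scatter), is of similar size. Both measured steps are modest and both were beyond the scatter.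

Compound 4, `O=C1c2ccccc2C(=O)N1CCOC(=S)N(C(=O)c1cccc2ccccc12)c1ccc(Cl)cc1`, has not yet been measured in this assay. It differs from compound 2 in one place: naphthalen-1-yl in place of 2,4-dichlorophenyl on a carbonyl carbon.

Neither measured step bears directly on this change. The step from compound 1 to compound 2 swapped halogens on the same ring; the step from compound 2 to compound 3 altered the other aromatic ring. Among the measured compounds shown here, neither involves a naphthalen-1-yl group, so the only guidance is that single changes at this part of the shared core have so far moved this assay by modest amounts. On that basis a step of no more than modest size is expected, with the direction uncertain, so the estimated step is a 1.2-fold higher number from compound 2 to compound 4 (0.09 log units; within the scatter). For compound 4 the expected value in this assay is 22000 nM, with a range from 8000 nM to 55000 nM.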

Compound 4, half-maximal cytotoxic concentration: 6000 nM
For compound 4 the middle estimate is 3.7-fold (0.56 log units) above the measured one; measured number below the stated range.
By their numbers in this assay, from the lowest: compound 4; then compound 2; then compounds 3 and 1 (each within the scatter of the next).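

In this assay, the carbonyl carbon whose other neighbour is the amide-type nitrogen now responds to replacing the ring itself, not only to exchanging the halogens on it: naphthalen-1-yl in place of 2,4-dichlorophenyl gives a 3.0-fold lower number from compound 2 to compound 4 (0.48 log units; beyond the scatter) in this comparison. Set against 2,4-difluorophenyl, the same group gives an 8.7-fold lower number from compound 1 to compound 4 (0.94 log units; beyond the scatter) as the largest step among the compounds shown. At this position the three groups therefore run from the lowest number upward as naphthalen-1-yl, 2,4-dichlorophenyl and 2,4-difluorophenyl, with every step between them beyond the scatter, although that order rests on only these three groups. No measurement at hand accounts for this order.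

On these data alone, it remains open whether naphthalen-1-yl would lower the number to a similar extent when paired with the methyl in place of chloro on an aromatic carbon, as carried by compound 3. Also open, as far as these compounds go, is how this assay would respond to a ring bearing an amine or a carboxylic acid on the carbonyl carbon, or to a saturated group such as cyclohexyl there.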